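A few compounds are considered here, and "the series" means these few. Any claim that something is new, unique, unknown or untested is made for them only; others in the source may bear on it.

Compound 2, `CCCc1ccc(/C=C/C(=O)Nc2ccc3nc(CCC)cc(N)c3c2)cc1`, gives 3600 nM in a functional assay on HEK293 cells for activation of melanin-concentrating hormone receptor 1 (Homo sapiens), read by inositol phosphate accumulation (a higher number here means that more compound is needed for the effect, a lower number that less compound is needed), the second highest of three measured numbers; compound 3, `Nc1cc(-c2ccccc2)nc2ccc(NC(=O)/C=C/c3ccc(C(F)(F)F)cc3)cc12`, gives 6600 nM, and compound 1, `CCCc1cc(N)c2cc(NC(=O)/C=C/c3ccc(Cl)cc3)ccc2n1`, gives 96 nM. Compound 4, `CCCc1cc(N)c2cc(NC(=O)/C=C/c3ccc(SC)cc3)ccc2n1`, differs from compound 2 by methylsulfanyl in place of propyl on an aromatic carbon. Within the data shown here, one measured step bears on this place: a 38-fold higher number from compound 1 to compound 2 (1.57 log units; beyond the scatter), a large rise when chloro gave way to propyl. Because that step a 38-fold higher number from compound 1 to compound 2 (1.57 log units; beyond the scatter) was large, and the methylsulfanyl group, with its two heavy atoms, is closer in count to chloro than to propyl, compound 4 is expected to move part of the way back toward compound 1, a drop of a 10-fold lower number from compound 2 to compound 4 (1.01 log units; beyond the scatter) in this assay. The estimate for compound 4 is 350 nM, within 100 nM to 1200 nM.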

Compound 4, half-maximal effective concentration: 71 nM
Beside the measured number, compound 4's estimate is 4.9-fold (0.69 log units) above it; measured number outside the range, below it.
By their numbers in this assay, from the lowest: compounds 4 and 1 (each within the scatter of the next); then compounds 2 and 3 (each within the scatter of the next).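

At this place on the aromatic ring, propyl is the odd one out: putting methylsulfanyl in its place recovers the whole loss seen earlier (a 51-fold lower number from compound 2 to compound 4 (1.71 log units; beyond the scatter)). Set against chloro, methylsulfanyl makes no difference beyond the scatter (a 1.4-fold lower number from compound 1 to compound 4 (0.13 log units; within the scatter)), so in this assay two unlike groups serve equally well here. No measured evidence explains why propyl stands apart.
As far as these compounds go, it remains open whether a shorter chain such as ethyl, a methoxy group or an amine would behave like chloro or like propyl. From the compounds shown here alone, the same swap on another core also remains open.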